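The source may report more compounds than this note shows. Statements on the series, on what has been measured and on what is new or still open speak of the compounds shown alone.

Compound 2, `Cc1ccc(-c2cc(C)c(Oc3cc(N)nc(Nc4ccc(C#N)cc4)n3)c(C)c2)cc1`, is the compound with the lowest number among the two measured in a toxicity assay on MT4 cells (Homo sapiens) for cytotoxicity, read by MTT assay; a lower number here means that less compound is tolerated, a higher number that more compound is tolerated: compound 2 gives 10000 nM. Among the measured compounds shown here, its only neighbour is compound 1, `Cc1cc(-c2ccccc2Cl)cc(C)c1Oc1cc(N)nc(Nc2ccc(C#N)cc2)n1`, which in this assay gives 25100 nM. For the measured compounds named here, the one measured step between them, a 2.5-fold lower number from compound 1 to compound 2 (0.40 log units; beyond the scatter), concerns a 4-methylphenyl in place of a 2-chlorophenyl on an aromatic carbon.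

Compound 3, `Cc1cc(-c2cccc(C#N)c2)cc(C)c1Oc1cc(N)nc(Nc2ccc(C#N)cc2)n1`, has not yet been measured. It differs from compound 2 by 3-cyanophenyl in place of 4-methylphenyl on an aromatic carbon. Going by the values given here, no measured step speaks to this particular exchange: the step from compound 1 to compound 2 swaps one aryl substituent for another on the same aromatic carbon, but neither of those aryl groups is the 3-cyanophenyl that enters here, so it serves only as a rough gauge that such swaps can move the number by a modest amount. On that basis compound 3 is expected to sit close to compound 2, with no step beyond the scatter, a 1.4-fold higher number from compound 2 to compound 3 (0.15 log units; within the scatter). For compound 3 in this assay the estimate is 14000 nM, within a range from 5000 nM to 40000 nM.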

Compound 3, half-maximal cytotoxic concentration: 20200 nM
Estimate against measurement, compound 3: 1.4-fold (0.16 log units) below; measured number inside the range.
By their numbers in this assay, from the lowest: compound 2; then compounds 3 and 1 (each within the scatter of the next).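

In this assay, 3-cyanophenyl in place of 4-methylphenyl on this aromatic carbon gives a 2.0-fold higher number from compound 2 to compound 3 (0.31 log units; beyond the scatter) and so lies just beyond the scatter, which means that a second aryl group now stands apart from 4-methylphenyl. Set against 2-chlorophenyl, the same group gives a 1.2-fold lower number from compound 1 to compound 3 (0.09 log units; within the scatter) and stays within the scatter, so these two aryl groups cannot be told apart here despite their different substituents, and of the three compounds only compound 2 is set off from both others. No evidence at hand bears on what lies behind this difference.

Going by these compounds, all three compounds carry a substituted phenyl group at this carbon, so it remains open whether the lower number of compound 2 goes with the methyl group itself or with its place on the ring, which a pair such as 3-methylphenyl and 4-chlorophenyl could help to separate. The compounds also leave open how the number would respond to a group without an aromatic ring at this carbon, such as a morpholine or a longer chain ending in an amine.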